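The compounds below may be only part of what the source reports. "The series", "measured", "known", "first", "only" and "open" are said of these compounds alone.

Compound 1 `FC(F)(F)c1ccc(Nc2ncnc3sc(Nc4c(Cl)cccc4Cl)nc23)cc1`: 12 nM
Compound 2 `FC(F)(F)c1ccc(Nc2nc(N3CCCC3)nc3sc(Nc4c(Cl)cccc4Cl)nc23)cc1`: 12 nM
Compound 3 `FC(F)(F)c1ccc(Nc2nc(N3CCNCC3)nc3sc(Nc4c(Cl)cccc4Cl)nc23)cc1`: 5000 nM

In a functional assay on HEK293 cells for antagonist activity at transient receptor potential cation channel subfamily V member 1 (Homo sapiens), read by calcium flux (on this read-out lower numbers stand for stronger inhibition and higher numbers for weaker inhibition), compound 3 gives the highest number of the three, that is the weakest inhibition: against compound 1 the step is a 420-fold higher number from compound 1 to compound 3 (2.62 log units; beyond the scatter), and against compound 2 it is a 420-fold higher number from compound 2 to compound 3 (2.62 log units; beyond the scatter). By contrast the step of no change at the digits printed from compound 1 to compound 2 (within the scatter) shows that putting a pyrrolidin-1-yl on that aromatic carbon of the shared core left the read-out alone, whereas the piperazin-1-yl did not.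

Compound 4 `CC(C)N1CCN(c2nc(Nc3ccc(C(F)(F)F)cc3)c3nc(Nc4c(Cl)cccc4Cl)sc3n2)CC1` keeps the piperazine ring of compound 3 and differs from it in one place: isopropyl in place of hydrogen on an amine nitrogen in a ring. For the measured compounds named here, no measured pair shows this exact change. What bears on it is that compound 2, whose ring amine carries no hydrogen, gives 12 nM in this assay, while compound 3, whose ring nitrogen does carry a hydrogen, gives 5000 nM. The isopropyl takes that hydrogen's place, so a move back towards lower numbers seems possible, but pyrrolidin-1-yl and 4-isopropylpiperazin-1-yl are not the same group, and the size cannot be read from these three compounds. A step down beyond the scatter, though not a full return to the level of compound 2, is expected. Compound 4 is therefore estimated at 400 nM, with a range from 40 nM to 4000 nM. That estimate means an expected step of a 13-fold lower number from compound 3 to compound 4 (1.10 log units; beyond the scatter).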

Compound 4, half-maximal inhibitory concentration: 184 nM
The estimate for compound 4 lay 2.2-fold (0.34 log units) above the measured number, within the range that was stated.
By their numbers in this assay, from the lowest: compounds 1 and 2 (each within the scatter of the next); then compound 4; then compound 3.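

Compound 4 shows that the piperazine ring does not by itself hold the read-out at the level of compound 3. In this assay, what sits on the amine nitrogen of that ring matters a great deal, since isopropyl in place of hydrogen there gives a 27-fold lower number from compound 3 to compound 4 (1.43 log units; beyond the scatter) and so recovers much of what the unsubstituted piperazin-1-yl lost. The recovery is only partial, however: 4-isopropylpiperazin-1-yl on the aromatic carbon gives a 15-fold higher number from compound 2 to compound 4 (1.19 log units; beyond the scatter) when it replaces pyrrolidin-1-yl and a 15-fold higher number from compound 1 to compound 4 (1.19 log units; beyond the scatter) when it replaces hydrogen, so this group does not match the flat result seen with pyrrolidin-1-yl. Nothing measured here gives a cause for the large effect of the isopropyl on this nitrogen.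

With only hydrogen and isopropyl shown on that nitrogen, it remains open whether a methyl, a cyclopropyl or an acetyl there would bring the number closer to those of compound 1 and compound 2. As far as these compounds go, it is also open how a morpholin-4-yl, with an oxygen in the place of that ring nitrogen, would read in this assay on the same aromatic carbon.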